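Notes on the series: from compound 3 to compound 4

This account rests on a few compounds, and the source may have more. Where it says the series, first, only, none or still open, it means among the compounds named here.

In a functional assay on K562 cells (Homo sapiens) for cytotoxicity, read by spectrophotometry (a lower number here means a stronger inhibitor, a higher number a weaker inhibitor), compound 3 `CC(=O)O[C@@H](C[C@@H]1C(C)=CCC(=O)C1(C)C)/C(C)=C/[C@H](O)C/C=C(\C)CC[C@H]1C(C)(C)[C@@H](O)CC[C@]1(C)OC(C)=O` gives 14600 nM, the lowest of the two numbers in hand. Compound 2 `CC(=O)O[C@@H](C[C@@H]1C(C)=CCC(=O)C1(C)C)/C(C)=C/[C@@H](C/C=C(\C)CC[C@H]1C(C)(C)[C@@H](O)CC[C@]1(C)OC(C)=O)OC(C)=O` gives 38900 nM, and the step of a 2.7-fold lower number from compound 2 to compound 3 (0.43 log units; beyond the scatter). Compound 1 `CC(=O)O[C@@H](C[C@@H]1C(C)=CCC(=O)C1(C)C)/C(C)=C/[C@H](O)C/C=C(\C)CC[C@H]1C(C)(C)[C@@H](O[C@@H]2O[C@H](CO)[C@H](O)[C@H](O)[C@H]2O)CC[C@]1(C)OC(C)=O` reaches only the limit of > 100000 nM and yields no number. The step of an at least 6.8-fold lower number from compound 1 to compound 3 (0.83 log units; beyond the scatter) is thus a bound rather than a measured difference, as recorded in the limit of > 100000 nM in this assay, at which 1 of the 3 values shown sits.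

Compound 4 `CC(=O)O[C@@H](C[C@H]1C(C)(C)C(=O)C=C[C@]1(C)O)/C(C)=C/[C@H](O)C/C=C(\C)CC[C@H]1C(C)(C)[C@@H](O)CC[C@]1(C)OC(C)=O` has not been measured. It differs from compound 3 in one place: 2-hydroxy-2,6,6-trimethyl-5-oxocyclohex-3-en-1-yl in place of 2,6,6-trimethyl-5-oxocyclohex-2-en-1-yl on a saturated chain carbon, two bonds along the chain from a double-bonded chain carbon and an oxygen next to a carbonyl group. Neither measured step touches this part of the molecule. Both an at least 6.8-fold lower number from compound 1 to compound 3 (0.83 log units; beyond the scatter) and a 2.7-fold lower number from compound 2 to compound 3 (0.43 log units; beyond the scatter) concern an oxygen on a saturated carbon elsewhere in the skeleton, and each replaced a group with hydrogen, whereas here a hydroxyl enters the ring and the ring double bond shifts. Among the measured compounds shown here, no measured pair therefore speaks to this change, and no step beyond the scatter is expected in this assay in either direction. Compound 4 is accordingly estimated at 15000 nM, with a range from 5000 nM to 45000 nM. The expected step of a 1.0-fold higher number from compound 3 to compound 4 (0.01 log units; within the scatter) amounts to essentially no change beyond the scatter.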

Compound 4, half-maximal inhibitory concentration: 27500 nM
Compound 4: middle estimate off by 1.8-fold (0.26 log units), on the low side; measured number inside the range.
By their numbers in this assay, from the lowest: compounds 3, 4 and 2 (each within the scatter of the next, the first and the last beyond it). At a limit, above all of these: compound 1.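

Among the compounds shown here, compound 4 gives the first reading of a change in the ring on a saturated chain carbon, two bonds along the chain from a double-bonded chain carbon and an oxygen next to a carbonyl group; both earlier steps concerned an oxygen on a saturated carbon elsewhere in the skeleton. In this assay, putting 2-hydroxy-2,6,6-trimethyl-5-oxocyclohex-3-en-1-yl in place of 2,6,6-trimethyl-5-oxocyclohex-2-en-1-yl gives a 1.9-fold higher number from compound 3 to compound 4 (0.27 log units; within the scatter), so at this position the added hydroxyl and the shifted ring double bond together leave the two compounds within the scatter of each other. Nothing in the data at hand bears on the reason for this reading.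

The hydroxyl and the shifted double bond arrive together, so the shown compounds do not separate what each contributes, nor do they show whether the opposite configuration at the new hydroxyl-bearing carbon would read the same. On these data alone, whether this ring position would also accept a methoxy group, an acetate on the new hydroxyl, an amine or a carboxylic acid remains open.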